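This account rests on a few compounds, and the source may have more. Where it says the series, first, only, none or still open, it means among the compounds named here.

Measured so far in an ADME assay on Vero cells (Chlorocebus sabaeus) for cytotoxicity, read by crystal violet staining; on this read-out higher numbers stand for lower toxicity in this test and lower numbers for higher toxicity in this test:
Compound 1, `CN(C)CCCN(/N=N/c1cc(F)ccc1F)c1ccccc1`: 7000 nM
Compound 2, `Cc1c(/N=N/c2cccc(C(F)(F)F)c2)ccc(NC[C@@H]2CCCN3CCCC[C@H]23)c1C`: 80000 nM
Compound 3, `CN(C)CCCN(/N=N/c1cc(F)ccc1F)c1cccc(C(F)(F)F)c1`: 30000 nM

Of these three numbers, compound 2 gives 80000 nM, the highest; compound 3 gives 30000 nM and compound 1 gives 7000 nM, both beyond the scatter from compound 2. Compound 1 and compound 3 share a core and differ in one place only: hydrogen in place of trifluoromethyl on an aromatic carbon. That change produced a 4.3-fold lower number from compound 3 to compound 1 (0.63 log units; beyond the scatter), so removing the trifluoromethyl made the compound more toxic in this test.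

Compound 4, `Cc1c(/N=N/c2ccccc2)ccc(NC[C@@H]2CCCN3CCCC[C@H]23)c1C`, is not yet measured. It stands to compound 2 as compound 1 stands to compound 3, the same change at the same kind of place: hydrogen in place of trifluoromethyl on an aromatic carbon. Compound 2 and compound 3 are built on different cores, and the difference between the two cores is not broken down here.

Because a 4.3-fold lower number from compound 3 to compound 1 (0.63 log units; beyond the scatter) lowered the number when this change was made once before, a step of about that size is expected again: a 4.0-fold lower number from compound 2 to compound 4 (0.60 log units; beyond the scatter), an expectation resting on a single earlier example and on nothing else. Compound 4 is therefore estimated at 20000 nM, within a range from 7000 nM to 60000 nM.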

Compound 4, half-maximal cytotoxic concentration: 60000 nM
Compound 4: the middle estimate sits 3.0-fold (0.48 log units) below what was measured; measured number inside the range.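

In this assay putting hydrogen in place of trifluoromethyl gave a 1.3-fold lower number from compound 2 to compound 4 (0.12 log units; within the scatter) on the core of compound 2, so on this core the change leaves no readable difference. The size of the step therefore did not carry over from one core to the other, and the gap between the two examples is larger than repeated measurement alone would be expected to produce: the same change on two cores in this assay, a 4.3-fold lower number (0.63 log units; beyond the scatter) from compound 3 to compound 1 and a 1.3-fold lower number (0.12 log units; within the scatter) from compound 2 to compound 4, 3.2-fold (0.51 log units) apart, beyond the scatter of two such steps

For the compounds shown here, with only two pairs, this shows that the step cannot simply be copied from one core to another in these compounds, but it does not show which part of the cores matters or what the change would do on a further core.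

The compounds shown carry only hydrogen or trifluoromethyl at this place on the aromatic ring, so the effect of a chlorine, a methoxy group or a nitrile there remains open. Also open, going by these compounds, is whether such groups would differ between the two cores in the same way.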